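Adding a fluoro to the benzoyl ring of compound 3

This account rests on a few compounds, and the source may have more. Where it says the series, first, only, none or still open, it means among the compounds named here.

Measured compounds:
Compound 1, `O=C(c1ccc(F)cc1)N1CCc2nc(COc3cccc(F)c3)oc2C1`, gives 78%.
Compound 2, `O=C(c1ccc(F)cc1)N1CCc2nc(COc3ccc(F)c(F)c3)oc2C1`, gives 40%.
Compound 3, `O=C(c1ccccc1)N1CCc2nc(COc3cccc(F)c3)oc2C1`, gives 73%.

These three compounds were tested in a functional assay on HEK293 cells for positive allosteric modulation of metabotropic glutamate receptor 5 (Homo sapiens), read by calcium flux; on this read-out higher numbers stand for larger maximal responses and lower numbers for smaller maximal responses. Compound 3 stands second highest of the three numbers, with compound 1 within the scatter of it and compound 2 well below it.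

Compound 4, `O=C(c1cccc(F)c1)N1CCc2nc(COc3cccc(F)c3)oc2C1`, has not yet been measured. It differs from compound 3 by fluoro in place of hydrogen on an aromatic carbon.

Two measured steps involve a fluoro on an aromatic carbon. The step of a number 38 percentage points lower from compound 1 to compound 2 (beyond the scatter) concerns the other ring of the shared core and says little about the benzoyl part. The step of a number 5 percentage points lower from compound 1 to compound 3 (within the scatter) concerns a fluoro on the same ring that is changed here, and it stayed within the scatter. On that basis the step from compound 3 to compound 4 is expected to be small, a number 1 percentage points lower from compound 3 to compound 4 (within the scatter), with no clear direction. Compound 4 is therefore estimated at 72%, with a range from 50% to 90%.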

Compound 4, largest response reached (reported as percent of maximum), in percent of the reference or control that the assay uses: 75%
For compound 4 the middle estimate is 3 percentage points below the measured one; the range from low to high includes it.
By their numbers in this assay, from the lowest: compound 2; then compounds 3, 4 and 1 (each within the scatter of the next).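

In this assay, the change to a 3-fluorophenyl group gives a number 2 percentage points higher from compound 3 to compound 4 (within the scatter), and the read-out cannot be told apart from that of the unsubstituted ring. Comparing the two fluoro placements on this ring gives a number 3 percentage points lower from compound 1 to compound 4 (within the scatter), so among compounds 1, 3 and 4 the benzoyl ring shows no measurable dependence on whether or where it carries a fluoro. The same exchange of hydrogen for fluoro therefore has a very different outcome on the other ring: the same change on two cores in this assay, a number 38 percentage points lower (beyond the scatter) from compound 1 to compound 2 and a number 2 percentage points higher (within the scatter) from compound 3 to compound 4, 40 percentage points apart, beyond the scatter of two such steps.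

From the compounds shown here alone, what remains open is whether groups other than fluoro on the benzoyl ring, such as a methoxy, a nitrile or an amine, would also stay within the scatter of compound 3. Also open, going by these compounds, is whether a chloro in place of the added fluoro of compound 2 would bring a step of similar size.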